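The source may report more compounds than this note shows. Statements on the series, on what has been measured and on what is new or still open speak of the compounds shown alone.

Among the compounds with values here, in a functional assay on U-373MG ATCC cells (Homo sapiens) for cytotoxicity, read by MTT assay, with a stated time of 72 h (a lower number here means a stronger inhibitor, a higher number a weaker inhibitor), compound 1 (`COc1cc(/C=C/C=O)cc(OC)c1OC/C=C(\C)CCC=C(C)C`) gives 8000 nM, the only number so far. Compound 2 (`C=C(C)CCOc1c(OC)cc(/C=C/CO)cc1OC`) reads only as a limit, > 100000 nM. Compound 3 (`CC(C)=CCC/C(C)=C/COc1ccc(/C=C/C(=O)O)cc1`) also reads only as a limit, > 100000 nM. Compound 4 (`COc1cc(/C=C/C=O)cc(OC)c1OCC=C(C)C`) keeps the core of compound 1 and differs in the chain: hydrogen in place of 3-methylbut-2-en-1-yl on a saturated chain carbon bound to a double-bonded chain carbon. Within the data shown here, no measured step sizes this change in this assay. A moderate weakening beyond the scatter is expected, with a 3.1-fold higher number from compound 1 to compound 4 (0.49 log units; beyond the scatter) as the estimated step. For compound 4 the estimated value is 25000 nM, with an expected range of 8000 nM to 100000 nM.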

Compound 4, half-maximal inhibitory concentration: 30000 nM
For compound 4 the middle estimate is 1.2-fold (0.08 log units) below the measured one, within the range that was stated.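

In this assay, the series gains its first sized step at this position, with hydrogen in place of 3-methylbut-2-en-1-yl giving a 3.8-fold higher number from compound 1 to compound 4 (0.57 log units; beyond the scatter). The 3-methylbut-2-en-1-yl group therefore contributes to the activity of compound 1, but compound 4 still gives a measured value without it. Steps involving values that are limits of the assay cannot be read: the limit of > 100000 nM in this assay, at which 2 of the 4 values shown sit.

On these data alone, whether a longer chain, such as farnesyl, would strengthen or weaken the activity of the shared core remains open. So does the effect of an amine at the end of the chain.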